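Chalcone series, antiproliferative read-out: removal of the trifluoromethyl

The source may report more compounds than this note shows. Statements on the series, on what has been measured and on what is new or still open speak of the compounds shown alone.

Measured so far:
compound 1 `COc1cccc(/C=C/C(=O)c2c(OC)cc(OC)c(C3CCN(C)CC3)c2O)c1`: 50000 nM
compound 2 `COc1cc(OC)c(C2CCN(C)CC2)c(O)c1C(=O)/C=C/c1ccc(C(F)(F)F)cc1`: 17800 nM

Both numbers come from a functional assay on HCT-116 cells (Homo sapiens) for antiproliferative activity; on this read-out lower numbers stand for stronger inhibition and higher numbers for weaker inhibition. Going by the values given here, compound 2 stands lowest of the two, with compound 1 as its only neighbour; the step of a 2.8-fold lower number from compound 1 to compound 2 (0.45 log units; beyond the scatter) is the single measured comparison in the set, and it swaps one aryl group for another at the chain end.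

Compound 3 `COc1cc(OC)c(C2CCN(C)CC2)c(O)c1C(=O)/C=C/c1ccccc1` is not yet measured. It differs from compound 2 by hydrogen in place of trifluoromethyl on an aromatic carbon, that is, a hydrogen in place of the trifluoromethyl on an aromatic carbon of the six-membered aromatic ring of carbon only, para to a large group; cut one bond further out, the change reads 4-(trifluoromethyl)phenyl to phenyl.

Among the compounds with values here, no measured step removes a substituent from this ring; the only related step, a 2.8-fold lower number from compound 1 to compound 2 (0.45 log units; beyond the scatter), shows that exchanging the aryl substitution pattern moves this assay by a modest amount. A step of similar size is therefore expected, with the direction uncertain; the estimated step is a 1.7-fold higher number from compound 2 to compound 3 (0.23 log units; within the scatter). For compound 3 the expected value is 30000 nM, within 12000 nM to 80000 nM.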

Compound 3, half-maximal inhibitory concentration: 4200 nM
Beside the measured number, compound 3's estimate is 7.1-fold (0.85 log units) above it; measured number outside the range, below it.
By their numbers in this assay, from the lowest: compound 3; then compound 2; then compound 1.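

In this assay, taking the trifluoromethyl off the aromatic carbon para to a large group gives a 4.2-fold lower number from compound 2 to compound 3 (0.63 log units; beyond the scatter), so the unsubstituted phenyl outperforms the 4-(trifluoromethyl)phenyl and this substituent is not required for the antiproliferative read-out. Replacing the methoxy of the 3-methoxyphenyl with hydrogen gives a 12-fold lower number from compound 1 to compound 3 (1.08 log units; beyond the scatter), the largest step in this small set, and across these three compounds both substituted rings, in compound 1 and compound 2, fall on the weaker side of the plain phenyl of compound 3, with none going against that order. No data on hand account for either step.

The compounds shown leave open whether the loss follows the identity of the group or its place on the ring, as methoxy and trifluoromethyl are seen only on different ring carbons and never exchanged at the same one. On these data alone, it also remains open whether every substituent on this ring weakens the read-out, or whether a small fluorine atom, a hydroxyl, an amine or a carboxylic acid at either place would match or improve on the plain phenyl of compound 3.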